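From a sulfonamide to a bromophenyl on the triazole

This account rests on a few compounds, and the source may have more. Where it says the series, first, only, none or still open, it means among the compounds named here.

Within the data shown here, compound 1 `Cc1ccc(S(=O)(=O)NCc2cn(C[C@H](O)[C@H]3OC(=O)C(OCc4ccccc4)=C3OCc3ccccc3)nn2)cc1` is the only compound in this set with a numerical result: in an ADME assay on HFF cells (Homo sapiens) for cytotoxicity, read by MTT assay, with a stated time of 72 h (a lower number here means a stronger inhibitor, a higher number a weaker inhibitor), compound 1 gives 50 nM. The two other measured compounds reached only the limit of the assay. Compound 2 `Cc1ccc(-c2cn(C/C=C3\OC(=O)C(OCc4ccccc4)=C3OCc3ccccc3)nn2)cc1` gives > 100000 nM in this assay, which is a limit and not a number. Compound 3 `COc1ccccc1-c1cn(C/C=C2\OC(=O)C(OCc3ccccc3)=C2OCc2ccccc2)nn1` likewise gives > 100000 nM in this assay, again a limit. Among the measured compounds shown here, the single measured step, a step that the two limits leave unreadable from compound 2 to compound 3, therefore cannot be read, since both of its ends sit at the limit of > 100000 nM in this assay, at which 2 of the 3 values shown sit.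

Compound 4 `O=C1O[C@H]([C@@H](O)Cn2cc(-c3ccc(Br)cc3)nn2)C(OCc2ccccc2)=C1OCc1ccccc1` has not yet been measured. It differs from compound 1 in one place: 4-bromophenyl in place of (((4-methylphenyl)sulfonyl)amino)methyl on an aromatic carbon. For the measured compounds named here, no measured step shares this change, so nothing in the data tells how large an effect to expect or in which direction. Compound 4 does carry an aryl group on the triazole, as compounds 2 and 3 do, while keeping the hydroxylated linker of compound 1, so its result could fall anywhere between the number for compound 1 and the limit. Compound 4 is therefore estimated at 5000 nM in this assay, with a wide range from 200 nM to 100000 nM. This estimate means a step of a 100-fold higher number from compound 1 to compound 4 (2.00 log units; beyond the scatter), expected as a loss of cytotoxic strength relative to compound 1.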

Compound 4, half-maximal inhibitory concentration: 5100 nM
Estimate against measurement, compound 4: 1.0-fold (0.01 log units) below, and the stated range covers the measured number.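

Among these compounds, the aromatic carbon of the five-membered ring with 3 nitrogen is the first place in this set where a change can be read as a size: 4-bromophenyl in place of (((4-methylphenyl)sulfonyl)amino)methyl gives a 100-fold higher number from compound 1 to compound 4 (2.01 log units; beyond the scatter). The group on this carbon therefore has a large influence on the result in this assay, and here the higher number means weaker inhibition of the cells. The swap changes several things at once, from 12 heavy atoms to 7, and from 1 hydrogen-bond donor and 2 acceptors to none, so this single step cannot show which of these differences matters. Among the compounds shown here, the one other step, between compound 2 and compound 3, still cannot be read, so the step from compound 1 stays the only sized comparison here: the limit of > 100000 nM in this assay, at which 2 of the 4 values shown sit. Going by these compounds, how the same carbon would respond to an amine, a carboxylic acid or a longer chain ending in a plain phenyl remains open, as does whether the bromine or the sulfonyl group contributes more to the gap.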